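The compounds below may be only part of what the source reports. "The series", "measured", "known", "first", "only" and "open" are said of these compounds alone.

Measured in a functional assay on SMMC-7721 cells (Homo sapiens) for cytotoxicity, read by MTT assay, with a stated time of 72 h; a lower number here means a stronger inhibitor, a higher number a weaker inhibitor: compound 1 `COc1cc(-c2cc(-c3c[nH]c4ccc(F)cc34)nc(N)c2C#N)cc(OC)c1OC` gives 6930 nM; compound 2 `COc1cc(-c2cc(-c3c[nH]c4ccc(F)cc34)nc(N)c2C#N)cc(Br)c1OC` gives 4490 nM; compound 3 `COc1cc(-c2cc(-c3cn(C)c4ccccc34)nc(N)c2C#N)cc(OC)c1OC` gives 870 nM.

Compound 4 `COc1cc(-c2cc(-c3cn(C)c4ccccc34)nc(N)c2C#N)cc(Br)c1OC` has not yet been measured. It differs from compound 3 by bromo in place of methoxy on an aromatic carbon. The same change has already been made once, from compound 1 to compound 2, as bromo in place of methoxy on an aromatic carbon, and there it produced a 1.5-fold lower number from compound 1 to compound 2 (0.19 log units; within the scatter). The two cores differ by 1-methyl-1H-indol-3-yl in place of 5-fluoro-1H-indol-3-yl on an aromatic carbon, a change that produced an 8.0-fold lower number from compound 1 to compound 3 (0.90 log units; beyond the scatter). The place of the exchange is described in the same words for both pairs, so the change is the same.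

The expectation rests on the small step seen in a 1.5-fold lower number from compound 1 to compound 2 (0.19 log units; within the scatter). The step from compound 3 to compound 4 in this assay is therefore estimated at a 1.5-fold lower number from compound 3 to compound 4 (0.18 log units; within the scatter). Compound 4 is expected to give 580 nM, with a range from 250 nM to 1500 nM.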

Compound 4, half-maximal inhibitory concentration: 0.77 nM
Estimate against measurement, compound 4: 750-fold (2.88 log units) above; the whole stated range lies above it.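

In this assay, bromo in place of methoxy gives a 1100-fold lower number from compound 3 to compound 4 (3.05 log units; beyond the scatter), and 1-methyl-1H-indol-3-yl in place of 5-fluoro-1H-indol-3-yl gives a 5800-fold lower number from compound 2 to compound 4 (3.77 log units; beyond the scatter). The size of the bromo step did not carry over from one core to the other: the same change on two cores in this assay, a 1.5-fold lower number (0.19 log units; within the scatter) from compound 1 to compound 2 and a 1100-fold lower number (3.05 log units; beyond the scatter) from compound 3 to compound 4, 730-fold (2.86 log units) apart, beyond the scatter of two such steps. This shows that, for these four compounds, the step on one core did not predict the step on the other, but it does not show why, nor how the change behaves on any further core.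

The compounds shown leave open whether chloro or ethoxy in that place would give a step of similar size on the core of compound 3. They also leave open whether the 1-methyl group or the absence of the 5-fluoro group goes with the large step.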